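The compounds below may be only part of what the source reports. "The series", "measured", "known", "first", "only" and "open" are said of these compounds alone.

Within the data shown here, in a functional assay on RT-112 cells (Homo sapiens) for antiproliferative activity, read by MTT assay, with a stated time of 72 h (on this read-out lower numbers stand for stronger inhibition of growth and higher numbers for weaker inhibition of growth), compound 1 `COc1cc(Nc2ncnc3c(NC(=O)Nc4cc(Cl)cc(Cl)c4)cccc23)cc(OC)c1` gives 30.2 nM, the only true number so far. Compound 2 `COc1cc(Nc2ncnc3c(NC(=O)Nc4ccc(C(F)(F)F)cc4[N+](=O)[O-])cccc23)cc(OC)c1` reads > 20000 nM, which is a limit of the assay and not a number. Compound 3 `COc1cc(Nc2ncnc3c(NC(=O)Nc4cccc(C)c4C)cccc23)cc(OC)c1` has not yet been measured. It keeps the rest of compound 1 but carries 2,3-dimethylphenyl in place of 3,5-dichlorophenyl on an amide-type nitrogen. Among the measured compounds shown here, no measured pair of compounds shows the size of a change like this, so any forecast must stay broad. With compound 1 already at 30.2 nM, a new group seems more likely to lose growth inhibition than to gain it. The expected change, a 17-fold higher number from compound 1 to compound 3 (1.22 log units; beyond the scatter), is therefore towards weaker inhibition and beyond the usual scatter. For compound 3 the estimated value is 500 nM, with an expected range of 60 nM to 5000 nM.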

Compound 3, concentration for 50% growth inhibition: 5910 nM
For compound 3 the middle estimate is 12-fold (1.07 log units) below the measured one; the measured number lies above the stated range.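

Compound 3 shows that the group on this amide-type nitrogen strongly affects the result in this assay: replacing 3,5-dichlorophenyl with 2,3-dimethylphenyl gives a 200-fold higher number from compound 1 to compound 3 (2.29 log units; beyond the scatter), even though both groups are six-membered carbon rings of equal heavy-atom count. Compound 2 reads > 20000 nM, which is a limit of the assay and not a number, so its step from compound 1 cannot be read. Nothing measured here accounts for the size of the step from the dichlorophenyl to the dimethylphenyl compound.

The compounds shown leave open whether the loss follows the change from chlorine to methyl or the change in where those groups sit on the ring, as both change together here. A 3,5-dimethylphenyl or 2,3-dichlorophenyl group on the same nitrogen would separate the two changes.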